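Adding a Ring Double Bond to Compound 1

The compounds below may be only part of what the source reports. "The series", "measured", "known", "first", "only" and "open" are said of these compounds alone.

Going by the values given here, in an ADME assay on the whole organism (strain Sprague-Dawley) with Rattus norvegicus as the target, at a dose of 0.5 mg/kg by the intravenous route (a lower number here means that the compound disappears faster, a higher number that the compound lasts longer), compound 1 `CC(C)(C)C#Cc1cc(N(C(=O)[C@H]2CC[C@H](C)CC2)[C@H]2CC[C@](O)(CO[C@H]3CCOC3)CC2)c(C(=O)O)s1` gives 3.8 h, the higher of the two numbers measured so far. Compound 2 `CC(C)(C)C#Cc1cc(N(C(=O)[C@H]2CC[C@H](C)CC2)[C@H]2CC[C@@H](Oc3cccnc3)CC2)c(C(=O)O)s1` gives 0.2 h, and that gap lies beyond the usual scatter of repeat measurements.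

Compound 3 `CC1=CC[C@H](C(=O)N(c2cc(C#CC(C)(C)C)sc2C(=O)O)[C@H]2CC[C@](O)(CO[C@H]3CCOC3)CC2)CC1` keeps the rest of compound 1 but carries 4-methylcyclohex-3-en-1-yl in place of 4-methylcyclohexyl on a carbonyl carbon. Both groups are six-membered non-aromatic rings of carbon only, and the entering one holds a double bond. Among the compounds with values here, no measured pair shows this change on its own, so the expectation rests only on how small the change is. The estimated step is small and downward, a 1.3-fold lower number from compound 1 to compound 3 (0.10 log units; within the scatter), and is expected to stay within the scatter. The mean residence time estimated for compound 3 is 3 h, with an expected range of 1.4 h to 6 h.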

Compound 3, mean residence time: 2.7 h
Estimate against measurement, compound 3: 1.1-fold (0.05 log units) above, and the stated range covers the measured number.
By their numbers in this assay, from the lowest: compound 2; then compounds 3 and 1 (each within the scatter of the next).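

Going by these compounds alone, this is the first step in which only one place changes: on a carbonyl carbon whose other neighbour is the amide-type nitrogen, 4-methylcyclohex-3-en-1-yl replaces 4-methylcyclohexyl, giving a 1.4-fold lower number from compound 1 to compound 3 (0.15 log units; within the scatter) in this assay. For this pair, then, the ring double bond leaves the mean residence time within the usual scatter, so the two compounds cannot be told apart in this measurement. Nothing at hand gives a reason for this result.

The compounds shown leave open whether a different group on this carbonyl carbon, such as a phenyl ring or an open chain like isopropyl, would move the number beyond the scatter. They also leave open whether the same double bond would give a similar step on the rest of compound 2.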